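Aryl for methyl on a ring nitrogen in electroshock testing

A few compounds are considered here, and "the series" means these few. Any claim that something is new, unique, unknown or untested is made for them only; others in the source may bear on it.

Measured compounds:
compound 1 `O=C1NC2(CC2c2ccc3cccc(OCc4ccccc4)c3n2)C(=O)N1c1ccc(C(F)(F)F)cc1`: 300 mg/kg
compound 2 `CN1C(=O)NC2(CC2c2ccc3cccc(OCc4ccccc4)c3n2)C1=O`: 100 mg/kg

In a functional assay on the whole organism (strain Kunming) with Mus musculus as the target, in the maximal electroshock model, with a stated time of 0.5 h (on this read-out higher numbers stand for an effect only at larger amounts of compound and lower numbers for an effect already at smaller amounts), compound 1 gives 300 mg/kg, while compound 2 gives 100 mg/kg, the lower of the two numbers. Among the compounds with values here, the single measured step is a 3.0-fold lower number from compound 1 to compound 2 (0.48 log units; beyond the scatter). Compound 3 `COc1ccc(N2C(=O)NC3(CC3c3ccc4cccc(OCc5ccccc5)c4n3)C2=O)cc1` differs from compound 2 by 4-methoxyphenyl in place of methyl on an amide-type nitrogen in a ring. Within the data shown here, this change reverses the direction of that step, putting an aromatic group back on the ring nitrogen, so a higher number is expected for compound 3, roughly a 2.0-fold higher number from compound 2 to compound 3 (0.30 log units; within the scatter), because a 3.0-fold lower number from compound 1 to compound 2 (0.48 log units; beyond the scatter) is the only guide available. Compound 3 is therefore estimated at 200 mg/kg in this assay, with a range from 100 mg/kg to 400 mg/kg.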

Compound 3, minimum effective dose: 30 mg/kg
Beside the measured number, compound 3's estimate is 6.7-fold (0.82 log units) above it; the whole stated range lies above it.
By their numbers in this assay, from the lowest: compound 3; then compound 2; then compound 1.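

In this assay, an aromatic group on this ring nitrogen does not by itself move the number one way: replacing methyl with 4-methoxyphenyl gives a 3.3-fold lower number from compound 2 to compound 3 (0.52 log units; beyond the scatter), the opposite direction to the earlier step with 4-(trifluoromethyl)phenyl. The group on that aromatic ring therefore matters, with methoxy in place of trifluoromethyl giving a 10-fold lower number from compound 1 to compound 3 (1.00 log units; beyond the scatter). Nothing available explains this difference. On these data alone, it remains open how a hydroxy group or a dimethylamino group at that aromatic carbon would compare, or how a benzyl group on the ring nitrogen would.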